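Swapping the aryl group on the hydrazide end

The source may report more compounds than this note shows. Statements on the series, on what has been measured and on what is new or still open speak of the compounds shown alone.

Compound 1, `O=C(N/N=C/c1c(-c2cc3ccccc3oc2=O)[nH]c2ccccc12)c1ccccc1`: > 200000 nM
Compound 2, `O=C(N/N=C/c1c(-c2cc3ccccc3oc2=O)[nH]c2ccccc12)c1cccc(Br)c1`: > 200000 nM

In a functional assay on MCF7 cells (Homo sapiens) for inhibition, read by MTT assay, with a stated time of 48 h (on this read-out lower numbers stand for stronger inhibition and higher numbers for weaker inhibition), compound 1 gives > 200000 nM, which is a limit of the assay and not a number. Compound 2, carrying bromo in place of hydrogen on an aromatic carbon, gives > 200000 nM, again a limit. The step that the two limits leave unreadable from compound 1 to compound 2 is therefore unreadable, as the limit of > 200000 nM in this assay, at which 2 of the 2 values shown sit, shows. Compound 3, `O=C(N/N=C/c1c(-c2cc3ccccc3oc2=O)[nH]c2ccccc12)c1ccc(Cl)cc1F`, differs from compound 2 by 4-chloro-2-fluorophenyl in place of 3-bromophenyl on a carbonyl carbon. Going by the values given here, with the only measured step unreadable, nothing here points to a change beyond the scatter. Compound 3 is thus expected to give 250000 nM, within 80000 nM to 1000000 nM, most likely again a limit. The expected step that the limit leaves unreadable from compound 2 to compound 3 is accordingly no readable change.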

Compound 3, half-maximal inhibitory concentration: > 200000 nM
Compound 3 was reported as a limit (the forecaster's own chance of this, stated with the estimate: 85%); the middle value does not contradict the limit.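

Compound 3 (> 200000 nM) is again a limit of the assay and not a number. Going by these compounds alone, no step among compound 1, compound 2 and compound 3 can therefore be read: the limit of > 200000 nM in this assay, at which 3 of the 3 values shown sit.

The compounds shown leave open whether any aryl group on the hydrazide end gives a readable number in this assay at all.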